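The source may report more compounds than this note shows. Statements on the series, on what has been measured and on what is new or still open speak of the compounds shown alone.

Compound 1 `O=C(Nc1ccccc1O)c1cccc(N2C(=O)c3ccccc3C2=O)c1` gives 77 nM in an in vitro functional assay on HEK293-A cells for antagonist activity at metabotropic glutamate receptor 5 (Rattus norvegicus), read by calcium flux (on this read-out lower numbers stand for stronger inhibition and higher numbers for weaker inhibition), and compound 2 `O=C(Nc1ccc(Cl)c(-c2nc3ccccc3[nH]2)c1)c1ccc(Br)o1` gives 85 nM. Compound 3 `COc1ccccc1C(=O)Nc1cccc(NC(=O)c2ccc(Cl)cc2)c1` stands apart from both: in this assay compound 3 yields only a limit of the assay, > 30000 nM, and no number, so that compound 3 marks (the limit of > 30000 nM in this assay, at which 1 of the 3 values shown sits). Compound 4 `COc1ccccc1C(=O)Nc1cccc(NC(=O)c2cc(Cl)cc(Cl)c2)c1` differs from compound 3 in one place, (3,5-dichlorophenyl in place of 4-chlorophenyl on a carbonyl carbon), that is, a 3,5-dichlorophenyl in place of a 4-chlorophenyl on a carbonyl carbon whose other neighbour is an amide-type nitrogen. For the measured compounds named here, no step between measured compounds is known here, so the size of the change from compound 3 to compound 4 in this assay cannot be read from any measured pair. The only anchor is the limit shown by compound 3, and with a second chlorine added while the shared core is kept, no movement beyond the scatter is expected. Compound 4 is therefore expected at about 30000 nM, between 8000 nM and 100000 nM, with a strong chance that this assay again reports only a limit. The estimated step of a number no higher from compound 3 to compound 4 (the limit leaves the size open) is expected to be nothing beyond the scatter.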

Compound 4, half-maximal inhibitory concentration: > 30000 nM
Compound 4: only a limit was reported (the forecaster's own chance of this, stated with the estimate: 70%); the middle value sits exactly at the limit.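

Like compound 3, compound 4 yields only a limit of the assay in this assay, > 30000 nM, so no step can be read from compound 3 to compound 4. The compounds shown leave open how strongly either compound inhibits, and whether 3,5-dichlorophenyl in place of 4-chlorophenyl changes that at all.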